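The source may hold more compounds than are shown below. What is called first, only, known or untested is meant among the compounds shown, and "the series" means these compounds.

Measured compounds:
- compound 1, `CN(C)CCCCCSC1=Nc2ccccc2C(CC(=O)NCc2ccc(F)cc2)N1c1ccc(-c2ccccc2)cc1`: 6400 nM
- compound 2, `CN(C)CCCCCSC1=Nc2ccccc2C(CC(=O)NCc2ccc(F)cc2)N1c1ccccc1`: 38800 nM

In a functional assay on HCT-116 cells (Homo sapiens) for cytotoxicity, read by MTT assay, with a stated time of 48 h (on this read-out higher numbers stand for weaker inhibition and lower numbers for stronger inhibition), compound 2 gives the highest of the two numbers; its nearest neighbour is compound 1, from which it differs by a 6.1-fold higher number from compound 1 to compound 2 (0.78 log units; beyond the scatter).

Compound 3, `CN(C)CCCCCSC1=Nc2ccccc2C(CC(=O)NCc2ccc(F)cc2)N1c1ccc(-c2ccc(F)cc2)cc1`, is not yet measured. It differs from compound 2 by 4-fluorophenyl in place of hydrogen on an aromatic carbon, the entering group sitting on an aromatic carbon of a six-membered aromatic ring of carbon only, para to a large group.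

Among the measured compounds shown here, the one measured step bearing on this change is a 6.1-fold higher number from compound 1 to compound 2 (0.78 log units; beyond the scatter), in which phenyl was replaced by hydrogen at the same place and the number rose well beyond the scatter. The step from compound 2 to compound 3 runs the other way, with 4-fluorophenyl entering where hydrogen stands, so a decrease of about the same size is expected, a 7.1-fold lower number from compound 2 to compound 3 (0.85 log units; beyond the scatter). For the measured compounds named here, no measured step addresses the fluorine itself. Compound 3 is therefore estimated at 5500 nM in this assay, within a range of 1800 nM to 17000 nM.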

Compound 3, half-maximal inhibitory concentration: 9300 nM
The estimate for compound 3 lay 1.7-fold (0.23 log units) below the measured number; measured number inside the range.
By their numbers in this assay, from the lowest: compounds 1 and 3 (each within the scatter of the next); then compound 2.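

In this assay, 4-fluorophenyl lowers the number just as phenyl does (a 4.2-fold lower number from compound 2 to compound 3 (0.62 log units; beyond the scatter)), so the lowering at this place is not tied to phenyl alone. Fluoro in place of hydrogen on the added ring stays within the scatter (a 1.5-fold higher number from compound 1 to compound 3 (0.16 log units; within the scatter)), so compound 1 and compound 3 cannot be ordered, and this single substitution on the added ring leaves the number unresolved from that of compound 1. Nothing at hand gives a reason for either step.

On these data alone, whether an aromatic ring is needed at all stays open, since a small group such as methyl or a saturated ring such as morpholine at this place would separate ring from size. Also open, as far as these compounds go, is whether an amine or a carboxylic acid on the added ring, in place of fluoro, would move the number beyond the scatter.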